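The source may hold more compounds than are shown below. What is called first, only, known or untested is meant among the compounds shown, and "the series" means these compounds.

In a functional assay on KM12 cells (Homo sapiens) for cytotoxicity, read by sulforhodamine B assay, with a stated time of 48 h, tested at 0.01 uM (on this read-out lower numbers stand for a stronger effect and higher numbers for a weaker effect at the one concentration tested), compound 1, with the structure `COc1cc(-c2cc(/C=C/C(=O)c3ccc(N)cc3)[nH]n2)cc(OC)c1OC`, gives 102%. Compound 2, whose structure is `COc1ccc(-c2cc(/C=C/C(=O)c3ccc(N)cc3)[nH]n2)cc1OC`, differs from compound 1 by a single change, (hydrogen in place of methoxy on an aromatic carbon), and in this assay compound 2 gives 102%. The step of no change at the digits printed from compound 1 to compound 2 (within the scatter) shows that this change left the read-out where it was.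

Compound 3, with the structure `COc1cc(C(=O)/C=C/c2cc(-c3cc(OC)c(OC)c(OC)c3)n[nH]2)cc(OC)c1OC`, has a different core; how that core differs from the core of compound 1 is not broken down here. In this assay compound 3 gives 101%, and its value, like those of compound 1 and compound 2, lies within the scatter of the others at the concentration tested.

Compound 4, whose structure is `COc1ccc(-c2cc(/C=C/C(=O)c3cc(OC)c(OC)c(OC)c3)[nH]n2)cc1OC`, has not yet been measured. Going by the values given here, it is reached from compound 3 by hydrogen in place of methoxy on an aromatic carbon, the same change as the one from compound 1 to compound 2, made around the same kind of place. Since that change gave no change at the digits printed from compound 1 to compound 2 (within the scatter) when made on the core of compound 1, and since compound 3 already stands at 101%, compound 4 is expected to show a step of about no change at the digits printed from compound 3 to compound 4 (within the scatter) in this assay. On this basis compound 4 is estimated to give 101% in this assay, with an expected range from 92% to 110%.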

Compound 4, a percentage reported as activity, at one concentration (the size of the read-out at that concentration, not a potency): 99%
Estimate against measurement, compound 4: 2 percentage points above, within the range that was stated.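

In this assay, putting hydrogen in place of methoxy on an aromatic carbon gave a step of a number 2 percentage points lower from compound 3 to compound 4 (within the scatter), and set beside the earlier case, the two steps do not differ: the same change on two cores in this assay, no change at the digits printed (within the scatter) from compound 1 to compound 2 and a number 2 percentage points lower (within the scatter) from compound 3 to compound 4, 2 percentage points apart, within the scatter of two such steps So, across these two cores, the change travelled without a difference that this read-out can resolve, and the result on the core of compound 1 was a fair guide to the result on the core of compound 3. This does not show that the methoxy group is without consequence in general: both steps lie within the scatter, all four compounds sit close together at the single concentration tested, and agreement between two steps that are this small says nothing about how the change would behave at another concentration or on a third core.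

The compounds shown leave open what other groups would do in the place of this methoxy, such as a hydroxyl, a fluorine, an amine or the longer ethoxy chain. They also leave open whether removing further methoxy groups from the same ring would shift the read-out on either core.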